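This account rests on a few compounds, and the source may have more. Where it says the series, first, only, none or still open, it means among the compounds named here.

Measured compounds:
compound 1, `Cc1ccc(-c2nnc(-n3[se]c4ccccc4c3=O)s2)cc1`, 16600 nM
compound 2, `COc1ccccc1-c1nnc(-n2[se]c3ccccc3c2=O)s1`, 14300 nM

Of the compounds shown here, two sharing the same core have been measured in a functional assay on SSMC-7721 cells (Homo sapiens) for antiproliferative activity, read by CCK-8 assay, with a stated time of 48 h; a lower number here means a stronger inhibitor, a higher number a weaker inhibitor. Among the measured compounds shown here, compound 1 gives 16600 nM, and compound 2 gives 14300 nM; the two numbers lie within the scatter of each other, so compound 1 cannot be set apart from compound 2 on these figures, and no step between the two has been worked out. Both compounds carry a single substituent on the six-membered aromatic ring of carbon only, and that substituent is where the next compound departs.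

Compound 3, `O=c1c2ccccc2[se]n1-c1nnc(-c2ccc(Cl)cc2)s1`, differs from compound 1 in one place: chloro in place of methyl on an aromatic carbon. The change keeps the count of heavy atoms, donors and acceptors unchanged, and it sits on an aromatic carbon of the same ring. For the measured compounds named here, with no measured step of this kind to lean on, the expected step from compound 1 to compound 3 in this assay is a 1.2-fold lower number from compound 1 to compound 3 (0.07 log units; within the scatter), that is, nothing beyond the usual scatter in either direction. Compound 3 is therefore expected to give about 14000 nM in this assay, with a plausible range from 6000 nM to 35000 nM.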

Compound 3, half-maximal inhibitory concentration: 24400 nM
Beside the measured number, compound 3's estimate is 1.7-fold (0.24 log units) below it; the measured number falls inside the stated range.
By their numbers in this assay, from the lowest: compounds 2, 1 and 3 (each within the scatter of the next).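

In this assay the exchange of methyl for chloro on an aromatic carbon of the six-membered aromatic ring, para to a large group, gives a 1.5-fold higher number from compound 1 to compound 3 (0.17 log units; within the scatter) and so leaves the 4-methylphenyl and 4-chlorophenyl compounds indistinguishable on these figures. Among the compounds shown here, this single step is the first direct reading of this position, which compounds 1 and 2 alone could not give, and it shows that one heavy atom can take the place of another here without a difference that stands clear of the scatter. No measurement among the data accounts for this result or bears on it.

The compounds shown cover only methyl and chloro at this position, so it remains open whether an amine, a carboxylic acid, a longer chain or a fused second ring in the same place would shift the number beyond the scatter. Also open, from the compounds shown here alone, is whether any change to the shared core, rather than to this substituent, would separate compounds in this assay more clearly than the swap from methyl to chloro does.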